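A few compounds are considered here, and "the series" means these few. Any claim that something is new, unique, unknown or untested is made for them only; others in the source may bear on it.

Compound 2 `CCN(CC)S(=O)(=O)c1ccc(S(=O)(=O)N2CCC[C@@H](C(=O)N3CCOCC3)C2)cc1` is one of two close relatives measured in a functional assay on MIA PaCa-2 cells (Homo sapiens) for inhibition, read by MTT assay, with a stated time of 3 days; a higher number here means a weaker inhibitor, a lower number a stronger inhibitor. In this assay compound 2 gives only a limit, > 10000 nM. Compound 1 `CCN(CC)S(=O)(=O)c1ccc(S(=O)(=O)N2CCC[C@@H](C(=O)N3CCC(O)CC3)C2)cc1` likewise gives only a limit in this assay, > 10000 nM. Within the data shown here, the one step between them, a step that the two limits leave unreadable from compound 1 to compound 2, cannot be read because both values sit at the limit of > 10000 nM in this assay, at which 2 of the 2 values shown sit. Compound 2 therefore stands at the edge of what this assay reports, with no number to place it against.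

The unmeasured compound 3 `CCN(CC)S(=O)(=O)c1ccc(S(=O)(=O)N2CCC[C@@H](C(=O)N3CC[C@@H](OC)C3)C2)cc1` differs from compound 2 in one place: 3-methoxypyrrolidin-1-yl in place of morpholin-4-yl on a carbonyl carbon. No measured step bears on this change; the single step shown is unreadable, so neither a direction nor a size can be drawn from it. With both measured relatives at a limit, the most that can reasonably be expected is that compound 3 stays near that limit. Compound 3 is estimated at 15000 nM in this assay, within 4000 nM to 50000 nM, the expected step being a step that the limit leaves unreadable from compound 2 to compound 3, and the result is expected most likely to be reported once more only as a limit.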

Compound 3, half-maximal inhibitory concentration: > 10000 nM
Compound 3: a limit, no number (the forecaster's own chance of this, stated with the estimate: 80%); the middle value is on the limit's open side.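

Compound 3, like compound 1 and compound 2, gives only a limit in this assay, so no step among the three can be read, because all of them sit at the same limit: the limit of > 10000 nM in this assay, at which 3 of the 3 values shown sit.

The compounds shown leave open whether morpholin-4-yl, 3-methoxypyrrolidin-1-yl and 4-hydroxypiperidin-1-yl differ at all in this assay, and whether any group on that carbonyl carbon would give a number there.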